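Swapping the aryl substituents in a TRPV1 antagonist series

The compounds below may be only part of what the source reports. "The series", "measured", "known", "first", "only" and "open" are said of these compounds alone.

Measured so far:
- compound 1 `CC1CCN(c2nc(C(F)(F)F)ccc2CNC(=O)C(C)c2cc(O)c(N)c(F)c2)CC1`: 5.3 nM
- compound 2 `COc1cc(C(C)C(=O)NCc2ccc(C(F)(F)F)nc2N2CCC(C)CC2)cc(OC)c1N`: 21 nM

In an assay on cells for antagonist activity at transient receptor potential cation channel subfamily V member 1 (Homo sapiens), read by FLIPR and calcium flux, with a stated time of 6 min (on this read-out lower numbers stand for stronger inhibition and higher numbers for weaker inhibition), compound 2 gives the highest of the two numbers; its nearest neighbour is compound 1, and the step of a 4.0-fold higher number from compound 1 to compound 2 (0.60 log units; beyond the scatter) is the only one measured. Compound 3 `CC1CCN(c2nc(C(F)(F)F)ccc2CNC(=O)C(C)c2cc(Cl)c(N)c(Cl)c2)CC1` differs from compound 2 by 4-amino-3,5-dichlorophenyl in place of 4-amino-3,5-dimethoxyphenyl on a saturated chain carbon bound to a carbonyl carbon and a saturated chain carbon. Among the measured compounds shown here, no measured step covers this exact exchange, but the step from compound 1 to compound 2 shows that groups on this ring matter modestly. Compound 3 is therefore expected to come closer to compound 1, giving an estimated 7 nM (range 2.5 nM to 20 nM), a step of a 3.0-fold lower number from compound 2 to compound 3 (0.48 log units; beyond the scatter).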

Compound 3, inhibition constant: 2.4 nM
The estimate for compound 3 lay 2.9-fold (0.46 log units) above the measured number; measured number outside the range, below it.
By their numbers in this assay, from the lowest: compound 3; then compound 1; then compound 2.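

In this assay the 4-amino-3,5-dichlorophenyl group gives an 8.8-fold lower number from compound 2 to compound 3 (0.94 log units; beyond the scatter) and also a 2.2-fold lower number from compound 1 to compound 3 (0.34 log units; beyond the scatter) as its second step. This position therefore needs neither the hydroxy group of compound 1 nor the methoxy groups of compound 2 for a low number, and among these three compounds, the ring with two chlorines gives the lowest. Nothing available gives a reason for this order. Still open, going by these compounds, is whether bromine atoms or methyl groups in place of the chlorines would lower the number further. On these data alone, all three compounds keep the amino group, so its own contribution also remains unknown.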